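Series notes: hydroxymethyl in place of pyridin-4-yl

The compounds below may be only part of what the source reports. "The series", "measured", "known", "first", "only" and "open" are said of these compounds alone.

Measured so far:
compound 1 `Fc1cccc(F)c1Cc1cnc(Nc2ccc(-c3ccncc3)c(Cl)c2)o1`: 9300 nM
compound 2 `Clc1cccc(Cl)c1Cc1nnc(Nc2ccc(COCc3ccncc3)cc2)o1`: 81000 nM

In an ADME assay on MT2 cells (Homo sapiens) for cytotoxicity, read by MTT assay (on this read-out higher numbers stand for lower toxicity in this test and lower numbers for higher toxicity in this test), compound 1 gives 9300 nM, the lowest of the two numbers. Compound 2 gives 81000 nM, a higher number, beyond the scatter.

Compound 3 `OCc1ccc(Nc2ncc(Cc3c(F)cccc3F)o2)cc1Cl` has not been measured. It differs from compound 1 as follows: hydroxymethyl in place of pyridin-4-yl on an aromatic carbon. No measured pair shows this change, so nothing shown supports a direction. A small shift toward a higher number is expected, about within the scatter, as the expected step of a 1.6-fold higher number from compound 1 to compound 3 (0.21 log units; within the scatter). Compound 3 is expected to give 15000 nM, with a range from 5000 nM to 50000 nM.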

Compound 3, half-maximal cytotoxic concentration: 90000 nM
The estimate for compound 3 lay 6.0-fold (0.78 log units) below the measured number; the whole stated range lies below it.
By their numbers in this assay, from the lowest: compound 1; then compounds 2 and 3 (each within the scatter of the next).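

In this assay, hydroxymethyl in place of pyridin-4-yl on this aromatic carbon, ortho to a chloro group, gives a 9.7-fold higher number from compound 1 to compound 3 (0.99 log units; beyond the scatter). The read-out at this position therefore responds to the substituent, and the aromatic ring is not required for a high number. No measurement shown accounts for the step. This single pair does not separate the loss of pyridin-4-yl from the arrival of hydroxymethyl. From the compounds shown here alone, how a methyl group, a carboxylic acid or a phenyl ring at this carbon would read remains open.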